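Removing the Propyl Group From the Core of Compound 2

The compounds below may be only part of what the source reports. "The series", "measured", "known", "first", "only" and "open" are said of these compounds alone.

Compound 1, `CCCc1c(OC)nc2nc(C(=O)c3ccccc3)cn2c1CC`: 10 mg/kg
Compound 2, `CCCc1c(OC)nc2nc(C(=O)c3ccccc3)cn2c1C`: 5 mg/kg

In a functional assay on the whole organism with Rattus norvegicus as the target (on this read-out higher numbers stand for an effect only at larger amounts of compound and lower numbers for an effect already at smaller amounts), compound 2 gives 5 mg/kg, the lowest of the two numbers shown. Among the measured compounds shown here, the only measured step is a 2.0-fold lower number from compound 1 to compound 2 (0.30 log units; within the scatter), a change on a saturated chain carbon.

Compound 3, `COc1cc(C)n2cc(C(=O)c3ccccc3)nc2n1`, differs from compound 2 by hydrogen in place of propyl on an aromatic carbon. For the measured compounds named here, no measured step removes a whole group from an aromatic carbon, and the one known step stays within the scatter, so it gives no direction for this change. Compound 3 is therefore expected to give 10 mg/kg, with a range from 3 mg/kg to 30 mg/kg. This estimate corresponds to an expected step of a 2.0-fold higher number from compound 2 to compound 3 (0.30 log units; within the scatter).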

Compound 3, minimum effective dose: 5 mg/kg
Compound 3: the middle estimate sits 2.0-fold (0.30 log units) above what was measured; the measured number falls inside the stated range.
By their numbers in this assay, from the lowest: compounds 2, 3 and 1 (each within the scatter of the next).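

Taking the propyl group off this aromatic carbon, ortho to a methoxy group and ortho to a methyl group, gives no change at the digits printed from compound 2 to compound 3 (within the scatter) in this assay on the whole animal. The earlier step touched only a saturated chain carbon, whereas this one shows that compound 3 keeps its number with hydrogen alone at this ring position, so propyl is not needed there for this read-out. No measurement at hand explains this result.

Only propyl and hydrogen can be compared at this carbon. As far as these compounds go, how an amine, a carboxylic acid or a longer chain such as hexyl would fare there stays open.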